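Compound 3 to compound 4: a new seven-membered ring

The compounds below may be only part of what the source reports. "The series", "measured", "known", "first", "only" and "open" are said of these compounds alone.

Compound 1 `O=C(Nc1ccc(F)c(Cl)c1)c1ccc(F)c(S(=O)(=O)N2CCSCC(O)C2)c1`: 19000 nM.
Compound 2 `CN1CCCN(S(=O)(=O)c2cc(C(=O)Nc3ccc(F)c(Cl)c3)ccc2F)CC1=O`: > 100000 nM, a limit of the assay.
Compound 3 `CC1(O)CCCN(S(=O)(=O)c2cc(C(=O)Nc3ccc(F)c(Cl)c3)ccc2F)CC1`: 11000 nM.

All three values come from an ADME assay on HepG2 2.2.15 cells (Homo sapiens) for cytotoxicity, read by luminescence, with a stated time of 3 days; a higher number here means that more compound is tolerated, a lower number that less compound is tolerated. In this assay compound 3 stands level with compound 1, since a 1.7-fold lower number from compound 1 to compound 3 (0.24 log units; within the scatter). It is far from compound 2, as an at least 9.0-fold lower number from compound 2 to compound 3 (0.95 log units; beyond the scatter).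

The next step leads to compound 4 `O=C(Nc1ccc(F)c(Cl)c1)c1ccc(F)c(S(=O)(=O)N2CCOC[C@@H](O)C2)c1`, in which 6-hydroxy-1,4-oxazepan-4-yl takes the place of 4-hydroxy-4-methylazepan-1-yl on a sulfonyl sulfur: 6-hydroxy-1,4-oxazepan-4-yl in place of 4-hydroxy-4-methylazepan-1-yl on a sulfonyl sulfur.

Within the data shown here, two measured steps bear on this change, and they disagree. The entering ring has 2 hetero atoms, as do the rings of compound 1 and compound 2. Yet a 1.7-fold lower number from compound 1 to compound 3 (0.24 log units; within the scatter), so leaving such a ring for the ring of compound 3 need not shift the number. By contrast, an at least 9.0-fold lower number from compound 2 to compound 3 (0.95 log units; beyond the scatter), so the same kind of exchange can also bring a large shift. Compound 1 therefore goes against any simple rule linking a second hetero atom to a higher number.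

A moderate rise in this assay is expected, with a 4.5-fold higher number from compound 3 to compound 4 (0.66 log units; beyond the scatter) as the estimated step. For compound 4 the estimated value is 50000 nM, with an expected range from 18000 nM to 100000 nM.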

Compound 4, half-maximal cytotoxic concentration: 14000 nM
Compound 4: middle estimate off by 3.6-fold (0.55 log units), on the high side; the measured number lies below the stated range.
By their numbers in this assay, from the lowest: compounds 3, 4 and 1 (each within the scatter of the next). At a limit, above all of these: compound 2.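

With the hydroxyl kept on the seven-membered ring, neither changing the ring's second hetero atom nor adding one gave a readable shift in this assay (a 1.3-fold higher number from compound 3 to compound 4 (0.10 log units; within the scatter); a 1.4-fold lower number from compound 1 to compound 4 (0.13 log units; within the scatter)). Compounds 1, 3 and 4, each with a hydroxyl on this ring on the sulfonyl sulfur, thus cannot be told apart here, and a second hetero atom alone does not set compound 4 apart from compound 3. Only 4-methyl-3-oxo-1,4-diazepan-1-yl, the one ring shown without a hydroxyl, remains clearly separate (an at least 7.1-fold lower number from compound 2 to compound 4 (0.85 log units; beyond the scatter)), and compound 2 stands at a limit of the assay: (the limit of > 100000 nM in this assay, at which 1 of the 4 values shown sits).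

The compounds shown leave open whether the separation of compound 2 goes with its ring carbonyl, its methyl on the ring nitrogen or the absence of the hydroxyl, as these features occur together in its ring. They also leave open how the mirror-image form of 6-hydroxy-1,4-oxazepan-4-yl would read, and whether an amine or a carboxylic acid in place of the hydroxyl on this ring would move the number in this assay.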